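Moving the Methoxy Group Around the Naphthalene

The source may report more compounds than this note shows. Statements on the series, on what has been measured and on what is new or still open speak of the compounds shown alone.

Measured compounds:
compound 1 `N#CC1=C(N)N(c2ccc(S(N)(=O)=O)cc2)C2=C(C(=O)CCC2)C1c1ccccc1` — 30%
compound 2 `N#CC1=C(N)N(c2ccc(S(N)(=O)=O)cc2)C2=C(C(=O)CCC2)C1c1ccc([N+](=O)[O-])cc1` — 80%
compound 3 `COc1ccc2ccccc2c1C1C(C#N)=C(N)N(c2ccc(S(N)(=O)=O)cc2)C2=C1C(=O)CCC2` — 62%

In a functional assay on Ehrlich cells (Mus musculus) for antiproliferative activity, read by trypan blue exclusion, with a stated time of 2 h, tested at 25 ug/mL (on this read-out higher numbers stand for a stronger effect at the one concentration tested and lower numbers for a weaker effect), compound 3 stands second highest of the three numbers. Compound 2 lies above it, as shown by a number 18 percentage points lower from compound 2 to compound 3 (beyond the scatter), and compound 1 lies below it, as shown by a number 32 percentage points higher from compound 1 to compound 3 (beyond the scatter).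

Compound 4 `COc1ccc(C2C(C#N)=C(N)N(c3ccc(S(N)(=O)=O)cc3)C3=C2C(=O)CCC3)c2ccccc12` is an isomer of compound 3: 4-methoxynaphthalen-1-yl in place of 2-methoxynaphthalen-1-yl on a saturated ring carbon. The measured steps that touch this saturated ring carbon, a number 32 percentage points higher from compound 1 to compound 3 (beyond the scatter) and a number 18 percentage points lower from compound 2 to compound 3 (beyond the scatter), exchange one aryl group for a different one; none of them merely shifts a substituent within the same naphthalene, so they give no direct guide. With nothing pointing either way, the step from compound 3 to compound 4 is expected to stay within the scatter, a number 2 percentage points lower from compound 3 to compound 4 (within the scatter). Compound 4 is therefore estimated at 60%, with a range from 40% to 80%.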

Compound 4, a percentage reported as activity, at one concentration (the size of the read-out at that concentration, not a potency): 10%
Compound 4: middle estimate off by 50 percentage points, on the high side; measured number below the stated range.
By their numbers in this assay, from the lowest: compound 4; then compound 1; then compound 3; then compound 2.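

In this assay, moving the methoxy group within the naphthalene is far from neutral even though the atoms stay the same: a number 52 percentage points lower from compound 3 to compound 4 (beyond the scatter) shows that 4-methoxynaphthalen-1-yl cannot stand in for 2-methoxynaphthalen-1-yl on this saturated ring carbon. The naphthalene alone therefore does not secure a gain over the phenyl of compound 1, as a number 20 percentage points lower from compound 1 to compound 4 (beyond the scatter) shows, and a number 70 percentage points lower from compound 2 to compound 4 (beyond the scatter) widens the gap to the 4-nitrophenyl of compound 2. Nothing available explains this drop. As far as these compounds go, whether a hydroxyl group or an amine in place of the methoxy group would restore the number of compound 3 remains open, and so does the reading of a nitro group on the naphthalene.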